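Phenyl for propyl on the ring nitrogen of compound 2

The compounds below may be only part of what the source reports. "The series", "measured", "known", "first", "only" and "open" are said of these compounds alone.

The series comprises two measured compounds. Compound 1 `CCn1c(=O)[nH]c2c(cnn2-c2cccc(Cl)c2)c1=N` shows the higher of the two numbers: in an assay on membranes from brain for binding affinity to adenosine receptor A1 (Rattus norvegicus), read by radioligand binding, tested at 20 uM (on this read-out lower numbers stand for less inhibition and higher numbers for more inhibition at the one concentration tested (going by the name of the read-out)), compound 1 gives 70%. Compound 2 `CCCn1ncc2c(=N)n(C)c(=O)[nH]c21` shows the lower, and in this assay compound 2 gives 5%, a difference that lies beyond the scatter. Among the compounds with values here, compound 2 thus stands lowest of the two numbers, with compound 1 as its only neighbour.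

The next compound, compound 3 `Cn1c(=O)[nH]c2c(cnn2-c2ccccc2)c1=N`, follows from compound 2 by a single change: phenyl in place of propyl on an aromatic nitrogen. Compound 1, whose structure stands above, likewise carries an aromatic substituent on the shared core and shows the higher reading, whereas compound 2 with its propyl shows the lower one. Within the data shown here, with only two compounds no step between measured pairs is at hand, so the direction rests on this comparison alone.

An upward step is expected, a number 45 percentage points higher from compound 2 to compound 3 (beyond the scatter), because compound 1 gives 70% while compound 2 gives 5%. Compound 3 is therefore estimated at 50%, with a range from 20% to 80%.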

Compound 3, a percentage reported as inhibition, at one concentration (the size of the read-out at that concentration, not a potency): 30%
Compound 3: the middle estimate sits 20 percentage points above what was measured; the measured number falls inside the stated range.
By their numbers in this assay, from the lowest: compound 2; then compound 3; then compound 1.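

In this assay, within the data shown here, the substituent on this aromatic nitrogen has a readable effect of its own: phenyl in place of propyl gives a number 25 percentage points higher from compound 2 to compound 3 (beyond the scatter), and this is the first step in which a single place changes while the rest of the structure stays the same. The counted features that change are limited to the ring and the heavy atoms: an aromatic ring of carbon only enters, the group grows from 3 to 6 heavy atoms, and neither group carries hydrogen-bond donors or acceptors, so this one pair cannot show which of these features goes with the step. Nothing at hand bears on the reason for the step.

On these data alone, whether the step belongs to the aromatic ring or simply to the larger group stays open, and a cyclohexyl ring, a benzyl group or a longer chain such as hexyl on this nitrogen would help to separate the two. Also open, as far as these compounds go, is how a substituent on the phenyl ring itself, such as a chlorine or a methoxy group, would act with the rest of compound 3 unchanged.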